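Sulfonamide tail change: hydroxyethyl to isobutyl

A few compounds are considered here, and "the series" means these few. Any claim that something is new, unique, unknown or untested is made for them only; others in the source may bear on it.

Measured compounds:
compound 1, `CC[C@@H]1C(=O)N(C)c2cnc(Nc3ccc(S(=O)(=O)NCCO)cc3)nc2N1C1CCCC1`: 7.86 nM
compound 2, `CC[C@@H]1C(=O)N(C)c2cnc(-n3ccc4cc(C(N)=O)ccc43)nc2N1C1CCCC1`: 28.5 nM
compound 3, `CCNC(=O)c1ccc2c(ccn2-c2ncc3c(n2)N(C2CCCC2)[C@H](CC)C(=O)N3C)c1`: 4.88 nM

All three were tested in an assay for inhibition of serine/threonine-protein kinase PLK2 (Homo sapiens), read by FRET and Z'-LYTE, with a stated time of 1 h; a lower number here means a stronger inhibitor, a higher number a weaker inhibitor. Compound 1 gives the second highest of the three numbers; compound 3 sits closest to it, within the scatter, while compound 2 lies furthest away, beyond the scatter. For the measured compounds named here, the one measured step between neighbours, a 5.8-fold lower number from compound 2 to compound 3 (0.77 log units; beyond the scatter), concerns a different part of the molecule, an amide-type nitrogen on the fused ring attached to the shared core, and does not touch the sulfonamide side chain.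

Compound 4, `CC[C@@H]1C(=O)N(C)c2cnc(Nc3ccc(S(=O)(=O)NCC(C)C)cc3)nc2N1C1CCCC1`, differs from compound 1 only at that side chain: isopropyl in place of hydroxymethyl on a saturated chain carbon bound to a sulfonamide nitrogen. Going by the values given here, no measured step bears on this position, so the estimate rests on compound 1 alone and on the observation that the three measured compounds stay within a fairly narrow band. The expected step of a 1.3-fold higher number from compound 1 to compound 4 (0.10 log units; within the scatter) is therefore small, with no clear direction beyond the scatter. Compound 4 is estimated at 10 nM, within a range from 3 nM to 35 nM.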

Compound 4, half-maximal inhibitory concentration: 21.8 nM
Compound 4: middle estimate off by 2.2-fold (0.34 log units), on the low side; the measured number falls inside the stated range.
By their numbers in this assay, from the lowest: compounds 3 and 1 (each within the scatter of the next); then compounds 4 and 2 (each within the scatter of the next).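

For the compounds shown here, this is the first measured change at the sulfonamide tail, and in this assay replacing 2-hydroxyethyl with isobutyl gives a 2.8-fold higher number from compound 1 to compound 4 (0.44 log units; beyond the scatter), so this position does respond to what is placed there. The response is modest, and the isobutyl compound remains measurable in the same nanomolar range as the other compounds shown. Nothing available here explains the weaker result of compound 4.

This single change removes the hydroxymethyl and brings in the isopropyl at once, leaving open which of the two matters more. A plain ethyl chain, a longer chain ending in a hydroxyl, or a chain ending in an amine or a carboxylic acid on the sulfonamide nitrogen could help separate those two parts of the change.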